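The source may report more compounds than this note shows. Statements on the series, on what has been measured and on what is new or still open speak of the compounds shown alone.

In a functional assay on THP-1 cells (Homo sapiens) for inhibition, read by sulforhodamine B assay, with a stated time of 48 h (on this read-out higher numbers stand for weaker inhibition and lower numbers for stronger inhibition), compound 1 (`C=CCC(O)(c1ccc(OC)c(OC)c1OC)c1cccc2ccccc12`) gives > 20000 nM, which is a limit of the assay and not a number. Among the compounds with values here, compound 2 (`COc1ccc(C(O)(Cc2ccc(F)cc2)c2cccc3ccccc23)c(OC)c1OC`) gives 5860 nM in this assay, the only actual number so far.

Compound 3 (`CCOC(=O)C(C)C(O)(c1ccc(OC)c(OC)c1OC)c1cccc2ccccc12`) differs from compound 2 at one place: 1-(ethoxycarbonyl)ethyl in place of 4-fluorobenzyl on a saturated chain carbon bound to two aromatic carbons and an oxygen on a saturated carbon. In words, 1-(ethoxycarbonyl)ethyl stands in place of 4-fluorobenzyl.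

Within the data shown here, one measured step bears on this change: an at least 3.4-fold lower number from compound 1 to compound 2 (0.53 log units; beyond the scatter), which lies beyond the scatter and brought in the 4-fluorophenyl. The move to compound 3 removes that aromatic ring, and the entering group has no ring. A partial reversal of an at least 3.4-fold lower number from compound 1 to compound 2 (0.53 log units; beyond the scatter) is therefore expected, meaning a modest move towards a higher number in this assay, possibly as far as the limit. Among the measured compounds shown here, no measured compound carries the ester, so this expectation is loose.

The expected change is a 2.4-fold higher number from compound 2 to compound 3 (0.38 log units; beyond the scatter). For compound 3 the estimated value is 14000 nM, with an expected range of 6000 nM to 30000 nM.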

Compound 3, half-maximal inhibitory concentration: > 20000 nM
Compound 3 ended at the assay's limit (the forecaster's own chance of this, stated with the estimate: 45%); middle value at least 1.4-fold (0.15 log units) away from the limit.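

In this assay, replacing 4-fluorobenzyl with 1-(ethoxycarbonyl)ethyl gives an at least 3.4-fold higher number from compound 2 to compound 3 (0.53 log units; beyond the scatter), so a second group without a ring, carrying two hydrogen-bond acceptors, joins allyl in showing no measurable inhibition, and among the compounds shown only the 4-fluorobenzyl group of compound 2 gives a number at this place on the saturated chain carbon. On these data alone, compound 3 gives > 20000 nM, which is a limit of the assay and not a number, so the true size of the loss stays unknown. The step from compound 1 to compound 3 cannot be read, and allyl and 1-(ethoxycarbonyl)ethyl cannot be ranked against each other, as the series is now largely pressed against the ceiling of the assay: the limit of > 20000 nM in this assay, at which 2 of the 3 values shown sit.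

Whether the aromatic ring or its fluorine accounts for the number at compound 2 remains open, and a plain benzyl group would separate the two. Also open, as far as these compounds go, is whether any group without a ring can give a number at this place, such as a longer alkyl chain, or an amine or a carboxylic acid in place of the ethyl ester.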